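From Diethylamino to Isopropylamino: An Expected Shift

A few compounds are considered here, and "the series" means these few. Any claim that something is new, unique, unknown or untested is made for them only; others in the source may bear on it.

Compound 1 `CCCCCCCNC(=N)NC(=N)Nc1ccc(F)c(F)c1`: 1500 nM
Compound 2 `CCN(CC)C(=N)NC(=N)Nc1ccc(F)c(F)c1`: 7800 nM
Compound 3 `CC(C)CNC(=N)NC(=N)Nc1ccc(C(F)(F)F)cc1`: 1300 nM

These three compounds were tested in a functional assay on A549 cells (Homo sapiens) for antiproliferative activity, read by MTT assay, with a stated time of 72 h; on this read-out lower numbers stand for stronger inhibition and higher numbers for weaker inhibition. Compound 2 gives the highest number of the three, so it inhibits the cells most weakly; compound 1 sits well below it, beyond the scatter, and compound 3 further still. Compound 4 `CC(C)NC(=N)NC(=N)Nc1ccc(F)c(F)c1` has not been measured. It differs from compound 2 in one place: isopropylamino in place of diethylamino on a carbon with a double bond to nitrogen. Going by the values given here, no measured pair shows exactly this step, so its size is uncertain. Because compound 1 gives 1500 nM and compound 3 gives 1300 nM, both far under compound 2, a downward step in this assay beyond the scatter is expected. Compound 4 is expected to give 2500 nM, within 1000 nM to 6000 nM. That corresponds to an expected 3.1-fold lower number from compound 2 to compound 4 (0.49 log units; beyond the scatter).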

Compound 4, half-maximal inhibitory concentration: 5200 nM
Compound 4: middle estimate off by 2.1-fold (0.32 log units), on the low side; the range from low to high includes it.
By their numbers in this assay, from the lowest: compounds 3 and 1 (each within the scatter of the next); then compounds 4 and 2 (each within the scatter of the next).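

In this assay the change from diethylamino to isopropylamino gives a 1.5-fold lower number from compound 2 to compound 4 (0.18 log units; within the scatter) and so does not separate these two groups at this place. Isopropyl in place of heptyl on the amine nitrogen gives a 3.5-fold higher number from compound 1 to compound 4 (0.54 log units; beyond the scatter) and this is the first measured sign that the group carried here can matter, with the longer heptyl chain on the side of the lower number. No measurement at hand explains either step. As far as these compounds go, whether a butyl chain or a cyclohexyl ring at this place would give numbers closer to those of heptyl or of isopropyl remains open.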